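This account rests on a few compounds, and the source may have more. Where it says the series, first, only, none or still open, it means among the compounds named here.

In a functional assay on NCI-H1993 cells (Homo sapiens) for inhibition, read by CCK-8 assay, with a stated time of 72 h (on this read-out higher numbers stand for weaker inhibition and lower numbers for stronger inhibition), three compounds sharing one core have been measured. Compound 1 `CC(c1cc2cccnc2cc1F)n1cnc2ncc(-c3ccncc3)nc21`, bearing pyridin-4-yl, gives 171 nM. Compound 2 `CC(c1cc2cccnc2cc1F)n1cnc2ncc(-c3ccccc3)nc21`, bearing phenyl, gives 570 nM. Compound 3 `CNC(=O)c1ccc(-c2cnc3ncn(C(C)c4cc5cccnc5cc4F)c3n2)cc1F`, bearing 3-fluoro-4-(methylcarbamoyl)phenyl, gives 32.7 nM, the lowest number of the three.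

Compound 4 `CC(c1cc2cccnc2cc1F)n1cnc2ncc(-c3cnc4ccccc4c3)nc21` has quinolin-3-yl in place of 3-fluoro-4-(methylcarbamoyl)phenyl on an aromatic carbon. Two measured steps introduce the departing group, and both lowered the number: the modest 5.2-fold lower number from compound 1 to compound 3 (0.72 log units; beyond the scatter) and the large 17-fold lower number from compound 2 to compound 3 (1.24 log units; beyond the scatter). The modest 3.3-fold higher number from compound 1 to compound 2 (0.52 log units; beyond the scatter) shows that the number also moves between the two simpler groups. Quinolin-3-yl itself has not been measured on this core, so compound 4 is judged against compound 1 and compound 2, which also lack the departing group.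

In this assay, a modest to large rise is therefore expected, with the estimated step being a 4.0-fold higher number from compound 3 to compound 4 (0.60 log units; beyond the scatter). Compound 4 is expected at about 130 nM, with an estimated range of 35 nM to 450 nM.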

Compound 4, half-maximal inhibitory concentration: 109 nM
Compound 4: the middle estimate sits 1.2-fold (0.08 log units) above what was measured; the range from low to high includes it.
By their numbers in this assay, from the lowest: compound 3; then compounds 4 and 1 (each within the scatter of the next); then compound 2.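

In this assay, a second fused aromatic ring is accepted at this position: quinolin-3-yl in place of phenyl gives a 5.2-fold lower number from compound 2 to compound 4 (0.72 log units; beyond the scatter) and, against pyridin-4-yl, a 1.6-fold lower number from compound 1 to compound 4 (0.20 log units; within the scatter), so these two nitrogen-bearing groups cannot be told apart here. Quinolin-3-yl, with no hydrogen-bond donor, still falls short of 3-fluoro-4-(methylcarbamoyl)phenyl, with a 3.3-fold higher number from compound 3 to compound 4 (0.52 log units; beyond the scatter), showing that the extra ring alone does not match the substituted phenyl on this read-out. No supporting data are available to explain these differences.

The compounds shown leave open whether the fluorine or the methylcarbamoyl group accounts for the standing of compound 3. They also leave open how a carboxylic acid or a morpholine ring on the phenyl would compare at this position.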